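The compounds below may be only part of what the source reports. "The series", "measured", "known", "first", "only" and "open" are said of these compounds alone.

Measured compounds:

- compound 1, `COc1cccc(CNCCCNc2ccnc3cc(Oc4ccc(F)cc4)ccc23)c1O`: 9.28
- compound 2, `COc1cccc(CNCCCNc2ccnc3cc(-c4ccccc4)ccc23)c1O`: 9.47
- compound 3, `COc1ccc(-c2ccc3c(NCCCNCc4cccc(OC)c4O)ccnc3c2)cc1`: 9.47

All three numbers come from a physicochemical assay for acid dissociation. Compound 3 sits level with compound 2 at the digits printed, and together they hold the highest value of the three; compound 1 lies lowest, yet its distance from compound 3 is within the scatter, so the three compounds cannot be told apart by this assay.

Compound 4, `COc1cccc(CNCCCNc2ccnc3cc(C4CCCCC4)ccc23)c1O`, has not yet been measured. It differs from compound 3 in one place: cyclohexyl in place of 4-methoxyphenyl on an aromatic carbon.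

Going by the values given here, three measured steps bear on this position of the shared core. Replacing the group there gave a number 0.19 log units higher from compound 1 to compound 2 (within the scatter) and a number 0.19 log units higher from compound 1 to compound 3 (within the scatter), and adding a methoxy to that group gave no change at the digits printed from compound 2 to compound 3 (within the scatter). Every one of these lies within the scatter. Exchanging one group for another at this carbon has so far left the acid dissociation constant unmoved, and cyclohexyl in place of 4-methoxyphenyl is expected to behave the same way.

Compound 4 is therefore expected to show a number 0.02 log units lower from compound 3 to compound 4 (within the scatter), nothing beyond the scatter. The estimate for compound 4 is 9.45, with a range from 9.1 to 9.8.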

Compound 4, acid dissociation constant: 9.47
Compound 4: the middle estimate sits 0.02 log units below what was measured; measured number inside the range.
By their numbers in this assay, from the lowest: compounds 1, 2, 3 and 4 (each within the scatter of the next).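

In this assay, going by these compounds alone, cyclohexyl is the first group at this carbon with no aromatic ring, and its exchange for 4-methoxyphenyl gives (no change at the digits printed from compound 3 to compound 4 (within the scatter)), while its exchange for phenyl, a swap of an aromatic ring for a non-aromatic one of the same size, gives (no change at the digits printed from compound 2 to compound 4 (within the scatter)). Its exchange for 4-fluorophenoxy gives (a number 0.19 log units higher from compound 1 to compound 4 (within the scatter)), so at this carbon the four compounds cannot be told apart, whether the six-membered ring is aromatic or not and whether the group carries oxygen or not. Nothing available explains why these exchanges make no measurable difference.

The compounds shown carry only ring groups of carbon at this position, so it remains open whether an amine or a carboxylic acid on this carbon, or a small group such as methyl, would also fall within the scatter of these four. All four also share everything outside this carbon, so they leave open which proton the number reports and how far a change elsewhere on the shared core, such as a longer chain, would move it.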